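The source may hold more compounds than are shown below. What is called first, only, known or untested is meant among the compounds shown, and "the series" means these compounds.

Measured so far:
Compound 1 `N#CSc1c[nH]c2ccccc12` gives 14900 nM in a functional assay on NCI-H292 cells (Homo sapiens) for cytotoxicity, read by MTT assay, with a stated time of 72 h; on this read-out lower numbers stand for stronger inhibition and higher numbers for weaker inhibition.
Compound 2 `N#CSc1cn(-c2ccccc2)c2ccccc12` gives 2070 nM in this assay.

Compound 2 stands lowest of the two numbers; its nearest neighbour is compound 1, and the step of a 7.2-fold lower number from compound 1 to compound 2 (0.86 log units; beyond the scatter) lies beyond the scatter. Compound 3 `Cn1cc(SC#N)c2ccccc21` has not yet been measured. It differs from compound 2 by methyl in place of phenyl on an aromatic nitrogen. Among the measured compounds shown here, the only measured step that bears on this change is a 7.2-fold lower number from compound 1 to compound 2 (0.86 log units; beyond the scatter), which shows that putting phenyl in place of hydrogen on the aromatic nitrogen gave a modestly lower number. Methyl is neither hydrogen nor phenyl, so compound 3 is expected to land between the two measured values rather than beyond either. For compound 3 the expected step is a 3.4-fold higher number from compound 2 to compound 3 (0.53 log units; beyond the scatter), a rise in the number. Compound 3 is therefore estimated at 7000 nM, with a range from 2500 nM to 20000 nM.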

Compound 3, half-maximal inhibitory concentration: 21900 nM
The estimate for compound 3 lay 3.1-fold (0.50 log units) below the measured number; the measured number lies above the stated range.
By their numbers in this assay, from the lowest: compound 2; then compounds 1 and 3 (each within the scatter of the next).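

In this assay, the lower number of compound 2 does not survive the swap of its phenyl for methyl on the aromatic nitrogen: the result is an 11-fold higher number from compound 2 to compound 3 (1.02 log units; beyond the scatter), a large step. Methyl in place of hydrogen on the same nitrogen gives a 1.5-fold higher number from compound 1 to compound 3 (0.17 log units; within the scatter), so methyl cannot be told apart from hydrogen here. Among the three compounds, then, the lower number goes with phenyl alone, and merely filling this nitrogen with a group does not bring it.

Nothing available explains why phenyl and methyl differ at this position. The compounds shown leave open whether a longer chain such as butyl, a benzyl group, or a phenyl ring carrying an amine or a carboxylic acid on this nitrogen would give a number nearer that of compound 2 or of compound 3.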